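A few compounds are considered here, and "the series" means these few. Any claim that something is new, unique, unknown or untested is made for them only; others in the source may bear on it.

Values in a functional assay on the whole organism with Mus musculus as the target; on this read-out lower numbers stand for an effect already at smaller amounts and higher numbers for an effect only at larger amounts of compound:

- compound 1 `Cc1ccccc1-c1ccc(N2CCC(O)CC2)nn1`: 40 mg/kg
- compound 2 `O=C1CCN(c2ccc(-c3ccccc3Cl)nn2)CC1`: 35 mg/kg

In this assay compound 2 stands at 35 mg/kg and compound 1 at 40 mg/kg, so the two values lie within the scatter of each other. Neither compound separates from the other on these numbers, and they differ in more than one place.

Compound 3 `O=C1CCN(c2ccc(-c3ccc(Cl)cc3Cl)nn2)CC1` is compound 2 with chloro in place of hydrogen on an aromatic carbon, para to a large group and meta to a chloro group: chloro in place of hydrogen on an aromatic carbon. For the measured compounds named here, no measured pair shows a single change of this kind, so any expectation here has little support. A small move towards a lower number, not beyond the scatter, is expected, with an expected step of a 1.2-fold lower number from compound 2 to compound 3 (0.07 log units; within the scatter). The estimate for compound 3 is 30 mg/kg, with an expected range from 13 mg/kg to 70 mg/kg.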

Compound 3, dose for half-maximal effect: 7.3 mg/kg
For compound 3 the middle estimate is 4.1-fold (0.61 log units) above the measured one; measured number outside the range, below it.
By their numbers in this assay, from the lowest: compound 3; then compounds 2 and 1 (each within the scatter of the next).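

In this assay, for the compounds shown here, the added chloro, para to a large group and meta to a chloro group, gives a 4.8-fold lower number from compound 2 to compound 3 (0.68 log units; beyond the scatter) and is the only single-place step so far. This position therefore responds to substitution, which compound 1 and compound 2 could not show, since they differ in more than one place and stay within the scatter of each other. Nothing measured here accounts for the size of this step.

Going by these compounds, whether the step belongs to chloro itself remains open, since one pair cannot separate it from what fluoro, methyl, methoxy or an amine would do at the same place. On these data alone, it is also open whether the same change would carry over to the core of compound 1.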